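Dropping a Chloro Group: What Happens to Cell Toxicity?

This account rests on a few compounds, and the source may have more. Where it says the series, first, only, none or still open, it means among the compounds named here.

Among the measured compounds shown here, compound 1 `O=C(Cn1c(=O)oc2cc(Cl)ccc21)Nc1nc2ccccc2s1` stands highest of the two compounds measured so far in an ADME assay on RAW264.7 cells (Mus musculus) for cytotoxicity, read by MTT assay, with a stated time of 72 h, tested at 50 uM (on this read-out higher numbers stand for a stronger effect at the one concentration tested and lower numbers for a weaker effect), where compound 1 gives 38.7%. The other measured compound, compound 2 `O=C(Cn1c(=O)oc2cc([N+](=O)[O-])ccc21)Nc1cc(C(F)(F)F)ccc1Cl`, gives 12.8% in this assay, a gap beyond the usual scatter. Compound 3 `O=C(Cn1c(=O)oc2ccccc21)Nc1nc2ccccc2s1` has not yet been measured. It differs from compound 1 in one place: hydrogen in place of chloro on an aromatic carbon. For the measured compounds named here, no measured pair shows this kind of change, so the expected step of a number 8.7 percentage points lower from compound 1 to compound 3 (within the scatter) is a cautious guess, leaning toward a modest drop that may still sit within the scatter. Compound 3 is therefore estimated to give 30%, within 15% to 45%.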

Compound 3, a percentage reported as inhibition, at one concentration (the size of the read-out at that concentration, not a potency): 43.5%
The estimate for compound 3 lay 13.5 percentage points below the measured number, within the range that was stated.
By their numbers in this assay, from the lowest: compound 2; then compounds 1 and 3 (each within the scatter of the next).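

Among the compounds shown here, this is the first comparison in which only one place differs: in this assay, hydrogen in place of chloro on this aromatic carbon gives a number 4.8 percentage points higher from compound 1 to compound 3 (within the scatter), so the two compounds cannot be told apart on this read-out. The chloro group is therefore not needed for the cell toxicity seen at the one concentration tested. Nothing available explains this result.

As far as these compounds go, whether this tolerance extends beyond hydrogen and chloro remains open. An amine or a carboxylic acid on this same aromatic carbon could give a clearly different number.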